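The source may report more compounds than this note shows. Statements on the series, on what has been measured and on what is new or still open speak of the compounds shown alone.

In a functional assay on Caco-2 cells (Homo sapiens) for inhibition, read by MTT assay, with a stated time of 48 h, tested at 10 uM (on this read-out higher numbers stand for more inhibition of growth at the one concentration tested and lower numbers for less inhibition of growth), compound 1 `Cc1cc(=O)c2c(O)c(CN3CCCC3)c(O)c([C@H]3CCN(C)C[C@H]3O)c2o1` gives 22%, and compound 2 `Cc1cc(=O)c2c(O)c(CN3CCCC3CO)c(O)c([C@H]3CCN(C)C[C@H]3O)c2o1` gives 19%, so compound 2 stands level with compound 1 within the scatter. Compound 3 `Cc1cc(=O)c2c(O)c(CN(C)CC(=O)O)c(O)c([C@H]3CCN(C)C[C@H]3O)c2o1` has yet to be measured. It keeps the shared core, but (carboxymethyl)(methyl)amino takes the place of 2-(hydroxymethyl)pyrrolidin-1-yl on a saturated chain carbon bound to an aromatic carbon: (carboxymethyl)(methyl)amino in place of 2-(hydroxymethyl)pyrrolidin-1-yl on a saturated chain carbon bound to an aromatic carbon. Among the compounds with values here, only one measured step bears on this change, a number 3 percentage points lower from compound 1 to compound 2 (within the scatter), which added hydroxymethyl in place of hydrogen on a saturated ring carbon. Within the data shown here, that step was small, but it says little about the change here, since no measured compound carries the entering group. The expected step, a number 2 percentage points lower from compound 2 to compound 3 (within the scatter), therefore stays within the scatter, with no clear direction. In this assay the estimate for compound 3 is 17%, with an expected range from 5% to 30%.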

Compound 3, percent growth inhibition at one concentration: 18%
The estimate for compound 3 lay 1 percentage points below the measured number; low and high end bracket the measured number.
By their numbers in this assay, from the lowest: compounds 3, 2 and 1 (each within the scatter of the next).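

In this assay, the open-chain (carboxymethyl)(methyl)amino group reads level with both ring-bearing groups it was compared with: the change from 2-(hydroxymethyl)pyrrolidin-1-yl gives a small step (a number 1 percentage points lower from compound 2 to compound 3 (within the scatter)), and the change from pyrrolidin-1-yl gives another (a number 4 percentage points lower from compound 1 to compound 3 (within the scatter)). On a saturated chain carbon bound to an aromatic carbon, the three compounds therefore show no separation between a group with one five-membered non-aromatic ring and a group with no ring, although only the entering group has a double bond outside aromatic rings. No measurement here bears on why these numbers stand level.

The compounds shown leave open whether a six-membered ring such as piperidin-1-yl or morpholin-4-yl would read any differently. They also leave open what an ester or amide in place of the carboxylic acid, or a longer chain carrying it, would do.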